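Sulfanyl in place of oxy on the shared core

The source may report more compounds than this note shows. Statements on the series, on what has been measured and on what is new or still open speak of the compounds shown alone.

Measured so far:
compound 1 `Nc1cc(N)c2nc(-c3ccccc3)c(Oc3ccc(Cl)c(Cl)c3)nc2c1` — 67600 nM
compound 2 `COc1cc(CNc2nc3cc(N)cc(N)c3nc2-c2ccccc2)cc(OC)c1OC` — a limit only, < 50200 nM

Going by the values given here, in a functional assay on COLO 205 cells (Homo sapiens) for inhibition, read by sulforhodamine B assay, with a stated time of 48 h (on this read-out higher numbers stand for weaker inhibition of growth and lower numbers for stronger inhibition of growth), compound 1 gives 67600 nM, the only number in hand for the series. Compound 2 reports no number in this assay, only the limit < 50200 nM. Compound 3 `Nc1cc(N)c2nc(-c3ccccc3)c(Sc3ccc(Cl)c(Cl)c3)nc2c1` is still to be measured in this assay; it differs from compound 1 by (3,4-dichlorophenyl)sulfanyl in place of 3,4-dichlorophenoxy on an aromatic carbon. Among the compounds with values here, no measured pair isolates this change, so the expected step is a 1.4-fold lower number from compound 1 to compound 3 (0.13 log units; within the scatter), not beyond the usual scatter. Compound 3 is therefore estimated at 50000 nM, within 20000 nM to 150000 nM.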

Compound 3, concentration for total growth inhibition: 33900 nM
Beside the measured number, compound 3's estimate is 1.5-fold (0.17 log units) above it; the range from low to high includes it.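

Across this assay, this is the first pair in the series that differs in one place, and it gives a 2.0-fold lower number from compound 1 to compound 3 (0.30 log units; within the scatter). At this position, on an aromatic carbon next to the ring nitrogen, (3,4-dichlorophenyl)sulfanyl and 3,4-dichlorophenoxy cannot be told apart on this read-out. Compound 2 remains a limit and not a number, and it offers no second reading of this change: the limit of < 50200 nM in this assay, at which 1 of the 3 values shown sits.

Open, on these data alone, is whether a sulfonyl or a methylene link at the same carbon would give a step beyond the scatter. Also open, as far as these compounds go, is whether the equivalence of sulfanyl and oxy holds with other aryl groups on the link.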